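Trading a 2-carboxyethyl chain for carbamoylmethyl

A few compounds are considered here, and "the series" means these few. Any claim that something is new, unique, unknown or untested is made for them only; others in the source may bear on it.

In a functional assay (trachea) with Cavia porcellus as the target (a higher number here means that more compound is needed for the effect, a lower number that less compound is needed), compound 1 `CCCn1c(=O)n(C)c(=O)c2[nH]cnc21` gives 1600 nM and compound 2 `CCCn1cnc2c1c(=O)n(C)c(=O)n2CCC` gives 5000 nM. Compound 3 `CCCn1c(=O)n(C)c(=O)c2c1ncn2CCC(=O)O` gives > 100000 nM, which is a limit of the assay and not a number. Compound 4 `CCCn1c(=O)n(C)c(=O)c2c1ncn2CC(N)=O` has not yet been measured in this assay. Its structure differs from that of compound 3 in one place: carbamoyl in place of carboxymethyl on a saturated chain carbon bound to an aromatic nitrogen. Put simply, the 2-carboxyethyl group gives way to carbamoylmethyl.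

Among the measured compounds shown here, three measured steps bear on this change. Propyl in place of hydrogen on an aromatic nitrogen gave a 3.1-fold higher number from compound 1 to compound 2 (0.49 log units; beyond the scatter), a modest step. With 2-carboxyethyl in place of that hydrogen the result was an at least 62-fold higher number from compound 1 to compound 3 (1.79 log units; beyond the scatter), a large step. Carboxy in place of methyl on a saturated chain carbon gave an at least 20-fold higher number from compound 2 to compound 3 (1.30 log units; beyond the scatter), also large. Both large steps came with the carboxy group, which compound 4 no longer carries. For the measured compounds named here, no measured compound yet has a carbamoyl group, so the size of the change remains uncertain. The expected result is an at least 6.6-fold lower number from compound 3 to compound 4 (0.82 log units; beyond the scatter), a step towards a lower number. For compound 4 the estimate is 15000 nM, with an expected range from 4000 nM to 60000 nM.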

Compound 4, half-maximal effective concentration: > 100000 nM
Compound 4 was reported as a limit (the forecaster's own chance of this, stated with the estimate: 20%); middle value at least 6.6-fold (0.82 log units) away from the limit.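

Compound 4, like compound 3, sits at a limit of the assay and not at a number, so the step between these two cannot be read and neither group can be placed ahead of the other in this assay: the limit of > 100000 nM in this assay, at which 2 of the 4 values shown sit.

Measured against the propyl chain, carbamoylmethyl gives an at least 20-fold higher number from compound 2 to compound 4 (1.30 log units; beyond the scatter) and measured against hydrogen on the aromatic nitrogen it gives an at least 62-fold higher number from compound 1 to compound 4 (1.79 log units; beyond the scatter) in the same assay. Both steps are large, so the carboxy group is not needed for a large rise in the number at this position: a chain ending in carbamoyl, which is also shorter than 2-carboxyethyl, lands at the same limit, while the propyl chain of compound 2 stays measurable.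

Going by these compounds, how far compound 3 and compound 4 really lie past the limit stays open, and a change of the same size or a real difference between them would look alike here. Also open, on these data alone, is whether a 2-aminoethyl chain, a methyl ester or a longer chain ending in carbamoyl at this nitrogen would bring the number back towards that of compound 2.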